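Changing the acyl group on the pyrrolidine of compound 3

This account rests on a few compounds, and the source may have more. Where it says the series, first, only, none or still open, it means among the compounds named here.

Measured so far:
Compound 1, `CN(C)CC(=O)N1CCC(NS(=O)(=O)c2cc(S(=O)(=O)c3ccccc3)ccc2C(F)(F)F)CC1` — 300 nM
Compound 2, `CC(C)(C)OC(=O)N1CCC[C@@H]1C(=O)N1CCC(NS(=O)(=O)c2cc(S(=O)(=O)c3ccccc3)ccc2C(F)(F)F)CC1` — 120 nM
Compound 3, `CC(=O)N1CCC[C@H]1C(=O)N1CCC(NS(=O)(=O)c2cc(S(=O)(=O)c3ccccc3)ccc2C(F)(F)F)CC1` — 160 nM

These three compounds share a core and differ only in the group attached to the carbonyl on the piperidine nitrogen. In an assay on isolated protein for binding affinity to secreted frizzled-related protein 1 (Homo sapiens), read by fluorescence (a higher number here means a weaker inhibitor, a lower number a stronger inhibitor), compound 3 stands second highest of the three numbers, with compound 2 nearest and compound 1 furthest; both of those gaps lie within the usual scatter, so the three compounds cannot be ranked against one another.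

Compound 4, `CN(C)c1ccc(C(=O)N2CCC[C@H]2C(=O)N2CCC(NS(=O)(=O)c3cc(S(=O)(=O)c4ccccc4)ccc3C(F)(F)F)CC2)cc1`, is the next compound. It differs from compound 3 in one place: 4-(dimethylamino)phenyl in place of methyl on a carbonyl carbon. The change sits at the same position that was altered between compound 2 and compound 3, where a 1.3-fold higher number from compound 2 to compound 3 (0.12 log units; within the scatter) was found, a step within the scatter. The earlier changes at the amide, a 2.5-fold lower number from compound 1 to compound 2 (0.40 log units; beyond the scatter) and a 1.9-fold lower number from compound 1 to compound 3 (0.27 log units; within the scatter), were at most modest. For the measured compounds named here, only one measured step touches the acyl position, so the expectation rests on a thin base.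

On that basis compound 4 is expected to show little change from compound 3, with a 1.2-fold lower number from compound 3 to compound 4 (0.09 log units; within the scatter) as the estimated step. The value expected for compound 4 in this assay is 130 nM, within a range from 50 nM to 350 nM.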

Compound 4, half-maximal inhibitory concentration: 110 nM
For compound 4 the middle estimate is 1.2-fold (0.07 log units) above the measured one; low and high end bracket the measured number.
By their numbers in this assay, from the lowest: compounds 4, 2, 3 and 1 (each within the scatter of the next, the first and the last beyond it).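

In this assay, replacing the methyl on the carbonyl carbon with 4-(dimethylamino)phenyl gives a 1.5-fold lower number from compound 3 to compound 4 (0.16 log units; within the scatter), so the two compounds cannot be told apart. For the compounds shown here, this is the first sign that a group carrying a six-membered aromatic ring can stand at this position without a step beyond the scatter, whereas the earlier swap at this position involved no aromatic ring. No measurement at hand explains why the number does not shift further.

From the compounds shown here alone, whether the dimethylamino group or the ring itself matters remains open, and an unsubstituted phenyl would be the direct test. A carboxylic acid on that ring or a longer alkyl chain on the carbonyl carbon could show how far this position's insensitivity extends.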